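From pentyl to benzyl on the aromatic nitrogen

The source may report more compounds than this note shows. Statements on the series, on what has been measured and on what is new or still open speak of the compounds shown alone.

compound 1 `COc1cc(-c2nccn2C)cc(OC)c1OC` gives > 100000 nM (a limit)
compound 2 `CCn1ccnc1-c1cc(OC)c(OC)c(OC)c1` gives > 100000 nM (a limit)
compound 3 `CCCCCn1ccnc1-c1cc(OC)c(OC)c(OC)c1` gives 34200 nM
compound 4 `COc1cc(-c2nccn2Cc2ccccc2)cc(OC)c1OC` is not yet measured

Within the data shown here, in a functional assay on MDA-MB-231 cells (Homo sapiens) for antiproliferative activity, read by MTT assay, with a stated time of 72 h (on this read-out higher numbers stand for weaker inhibition and lower numbers for stronger inhibition), compound 3 gives 34200 nM as the only number of the set. The values of compound 1 and compound 2 are limits of the assay, not numbers.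

Compound 4 carries phenyl in place of butyl on a saturated chain carbon bound to an aromatic nitrogen. The bearing steps are an at least 2.9-fold lower number from compound 1 to compound 3 (0.46 log units; beyond the scatter) and an at least 2.9-fold lower number from compound 2 to compound 3 (0.46 log units; beyond the scatter), each measured from a limit. Alongside them stands a step that the two limits leave unreadable from compound 1 to compound 2. None of these puts a ring at that place, so the reading rests on compound 3 alone. The expected change is a 1.1-fold lower number from compound 3 to compound 4 (0.06 log units; within the scatter), which would stay within the scatter. For compound 4 the estimate is 30000 nM, with an expected range of 10000 nM to 90000 nM.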

Compound 4, half-maximal inhibitory concentration: > 100000 nM
Compound 4: no number, only a limit; the forecaster's own chance of this, stated with the estimate: 20%; middle value at least 3.3-fold (0.52 log units) from the limit.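

In this assay, pentyl to benzyl at this place gives an at least 2.9-fold higher number from compound 3 to compound 4 (0.46 log units; beyond the scatter). More carbon on the aromatic nitrogen therefore does not by itself keep a measurable value, and compound 4 goes against the reading of the earlier steps as a gain with chain growth. The steps to compound 4 from compound 1 and compound 2 cannot be read, and the series sits mostly at one ceiling: the limit of > 100000 nM in this assay, at which 3 of the 4 values shown sit.

Only compound 3 gives a number, so no trend in chain length can be drawn. Open, going by these compounds, is whether a longer chain such as octyl, or a phenethyl group, falls under that limit.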